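Working notes: a shorter alkenyl chain on compound 2

The source may hold more compounds than are shown below. What is called first, only, known or untested is meant among the compounds shown, and "the series" means these compounds.

Measured in a functional assay on HeLa cells (Homo sapiens) for antiproliferative activity, read by XTT assay, with a stated time of 72 h; on this read-out higher numbers stand for weaker inhibition and lower numbers for stronger inhibition:
- compound 1 `C=C(C)CC[C@]1(C)C2=CCC[C@](C)(C[C@H](O)c3ccoc3)[C@H]2CC[C@H]1C`: 30200 nM
- compound 2 `C=C(C)CCC[C@]1(C)C2=CCC[C@](C)(C[C@H](O)C3=CC(=O)OC3O)[C@H]2CC[C@H]1C`: 3800 nM

Compound 2 holds the lower of the two numbers, and the gap to compound 1 lies beyond the scatter. Compound 3 `C=C(C)CC[C@]1(C)C2=CCC[C@](C)(C[C@H](O)C3=CC(=O)OC3O)[C@H]2CC[C@H]1C` carries 1-methylethenyl in place of 2-methylprop-2-en-1-yl on a saturated chain carbon, two bonds along the chain from a saturated ring carbon. Going by the values given here, no measured pair isolates this change. The estimated 1.2-fold higher number from compound 2 to compound 3 (0.07 log units; within the scatter) in this assay is expected to be no step beyond the scatter. For compound 3 the estimated value is 4500 nM, with an expected range of 1800 nM to 11000 nM.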

Compound 3, half-maximal inhibitory concentration: 4800 nM
Estimate against measurement, compound 3: 1.1-fold (0.03 log units) below, within the range that was stated.
By their numbers in this assay, from the lowest: compounds 2 and 3 (each within the scatter of the next); then compound 1.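

In this assay, 1-methylethenyl in place of 2-methylprop-2-en-1-yl gives a 1.3-fold higher number from compound 2 to compound 3 (0.10 log units; within the scatter), so this shorter alkenyl chain brings no step beyond the scatter. With the chain now the same, the non-aromatic five-membered ring group in place of the aromatic one gives a 6.3-fold lower number from compound 1 to compound 3 (0.80 log units; beyond the scatter), a modest step isolated at a single place. No measurement here explains either step.

Still open, on these data alone, is how a longer chain, an amine or a carboxylic acid would read in place of 1-methylethenyl. As far as these compounds go, whether the chain change reads the same alongside the aromatic ring group of compound 1 also remains open.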